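The compounds below may be only part of what the source reports. "The series", "measured", "known", "first", "only" and "open" are said of these compounds alone.

Series notes. In a functional assay on WiDr cells (Homo sapiens) for inhibition, read by sulforhodamine B assay, with a stated time of 48 h (on this read-out lower numbers stand for stronger inhibition of growth and higher numbers for weaker inhibition of growth), compound 1 `O=C(/C=C/c1ccccc1)OCC1COCCOCCOCCOCCOCCO1` gives only a limit of the assay, > 100000 nM, and not a number. Compound 2 `O=C(CCCCC1CCCCC1)OCC1COCCOCCOCCO1` likewise stands at a limit in this assay, > 100000 nM. Compound 3 `O=C(CCCc1cc2ccccc2[nH]1)OCC1COCCOCCOCCOCCOCCO1` too shows only a limit in this assay, > 100000 nM. So far every value shown sits at the same place: the limit of > 100000 nM in this assay, at which 3 of the 3 values shown sit. Among the compounds with values here, no measured pair differs in a single place, so no measured step is available, and the position of compound 1 can be stated only as a limit shared with compound 2 and compound 3.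

Compound 4 `O=C(OCC1COCCOCCOCCOCCOCCO1)c1cccnc1` is not yet measured in this assay. Its difference from compound 1 is pyridin-3-yl in place of 2-phenylethenyl on a carbonyl carbon. The ester linkage and the macrocyclic polyether core of compound 1 are retained unchanged.

Within the data shown here, with three limits and no measured step, there is no basis for expecting a step beyond the scatter in this assay; the expected step from compound 1 to compound 4 is a step that the limit leaves unreadable from compound 1 to compound 4, that is, essentially none. Compound 4 is therefore expected to fall around 150000 nM in this assay, within a range of 50000 nM to 500000 nM, and most probably the read-out will again be reported as a limit rather than as a number.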

Compound 4, concentration for 50% growth inhibition: > 100000 nM
Compound 4 gave a limit, no number (the forecaster's own chance of this, stated with the estimate: 80%); the middle value lies beyond the limit too.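

No step can be read between compound 1 and compound 4 in this assay, because both give only a limit and no number: the limit of > 100000 nM in this assay, at which 4 of the 4 values shown sit.

The compounds shown leave open whether any group on the carbonyl carbon of the shared core would give a number rather than a limit in this assay, and how far these compounds lie beyond that limit.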